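The source may hold more compounds than are shown below. What is called first, only, known or untested is meant among the compounds shown, and "the series" means these compounds.

Measured so far in an assay on isolated protein for displacement of a labelled ligand from metabotropic glutamate receptor 5 (Homo sapiens), with a stated time of 60 min, tested at 1 uM; on this read-out lower numbers stand for less inhibition and higher numbers for more inhibition at the one concentration tested (going by the name of the read-out):
compound 1, `CC1CCN(c2c(S(=O)(=O)c3ccc(C#N)cc3)cnc3cc(F)ccc23)CC1`: 83%
compound 2, `Cc1ccc2ncc(S(=O)(=O)c3ccccc3)c(N3CCC(C)CC3)c2c1`: 67%

Two compounds sharing the same core have been run in this assay. Compound 1 gives 83%, the higher of the two numbers. Compound 2 gives 67%, and the gap between the two values is larger than the usual scatter of repeated measurements, so compound 1 stands clearly above compound 2 on what has been measured. The two differ in more than one place, so nothing is drawn from that pair about any single change.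

Compound 3, `CC1CCN(c2c(S(=O)(=O)c3ccc(F)c(F)c3)cnc3cc(F)ccc23)CC1`, has not yet been measured in this assay. It differs from compound 1 in one place: 3,4-difluorophenyl in place of 4-cyanophenyl on a sulfonyl sulfur.

Going by the values given here, no measured pair isolates this change, so its size can only be guessed. A small downward step is expected, one that may not clearly exceed the scatter: the expected step is a number 11 percentage points lower from compound 1 to compound 3 (beyond the scatter). Compound 3 is accordingly estimated at 72% in this assay, with a likely range from 48% to 90%.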

Compound 3, a percentage reported as inhibition, at one concentration (the size of the read-out at that concentration, not a potency): 94%
Compound 3: middle estimate off by 22 percentage points, on the low side; the whole stated range lies below it.
By their numbers in this assay, from the lowest: compound 2; then compound 1; then compound 3.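

In this assay, 3,4-difluorophenyl in place of 4-cyanophenyl on a sulfonyl sulfur gives a number 11 percentage points higher from compound 1 to compound 3 (beyond the scatter). Going by these compounds alone, this is the first comparison here that isolates a single place, and it shows that the aromatic group on the sulfonyl sulfur can shift the read-out by more than the usual scatter, and that a nitrile on this group is not required for a high number: compound 3, which has no nitrile, gives 94%. Nothing available on these compounds accounts for the direction of this step.

The compounds shown leave open whether the step comes from losing the 4-cyanophenyl group or from gaining the 3,4-difluorophenyl group, and a 4-fluorophenyl or 4-methoxyphenyl group on the sulfonyl sulfur would help to separate the two. They also leave open whether the step would hold on the other substituents of the shared core, and how it would translate into potency, as the read-out comes from a single concentration.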